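This account rests on a few compounds, and the source may have more. Where it says the series, first, only, none or still open, it means among the compounds named here.

Compounds measured in an ADME assay on microsomes from liver (Homo sapiens) for metabolic stability, read by LC-MS, using NADPH, with a stated time of 45 min; a higher number here means that the compound lasts longer, a lower number that the compound disappears faster:

Compound 1, `COc1cnc(O[C@@H]2C[C@H]3C(=O)N[C@]4(C(=O)NS(=O)(=O)C5CC5)C[C@H]4/C=C\CCCCC[C@H](NC(=O)OC(C)(C)C)C(=O)N3C2)c2cc(Cl)ccc12`: 0.107 h
Compound 2, `COc1cnc(O[C@@H]2C[C@H]3C(=O)N[C@]4(C(=O)NS(=O)(=O)C5CC5)C[C@H]4/C=C\CCCC[C@@H](C)[C@H](NC(=O)OC(C)(C)C)C(=O)N3C2)c2cc(Cl)ccc12`: 0.192 h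
Compound 3, `CC[C@@H]1C[C@H](C)CC/C=C\[C@@H]2C[C@@]2(C(=O)NS(=O)(=O)C2CC2)NC(=O)[C@@H]2C[C@@H](Oc3ncc(OC)c4ccccc34)CN2C(=O)[C@H]1NC(=O)OC(C)(C)C(F)(F)F`: 0.628 h

In this assay compound 1 gives 0.107 h. Compound 2 differs from compound 1 by methyl in place of hydrogen on a saturated ring carbon; in this assay compound 2 gives 0.192 h. The step is a 1.8-fold higher number from compound 1 to compound 2 (0.25 log units; within the scatter). Compound 3 gives 0.628 h, the highest of the three, lying beyond the scatter from both compound 2 and compound 1. The difference between the core of compound 3 and the core of compound 1 is not broken down here.

Compound 4, `CC[C@@H]1C[C@H](C)CC/C=C\[C@@H]2C[C@@]2(C(=O)NS(=O)(=O)C2(C)CC2)NC(=O)[C@@H]2C[C@@H](Oc3ncc(OC)c4ccccc34)CN2C(=O)[C@H]1NC(=O)OC(C)(C)C(F)(F)F`, has not yet been measured. It differs from compound 3 by methyl in place of hydrogen on a saturated ring carbon. This is the same kind of change as that from compound 1 to compound 2, but not the same change: in compound 2 the methyl sits on a saturated ring carbon of a 15-membered non-aromatic ring with 2 nitrogen, next to the ring atom that bears a (tert-butoxycarbonyl)amino group, whereas in compound 4 it sits on a saturated ring carbon of a three-membered non-aromatic ring of carbon only, turning cyclopropylsulfonyl into (1-methylcyclopropyl)sulfonyl.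

Among the compounds with values here, the only measured precedent for a methyl in place of hydrogen on a saturated ring carbon is the step of a 1.8-fold higher number from compound 1 to compound 2 (0.25 log units; within the scatter), which stayed within the scatter. Resting on that, the expected step is a 1.4-fold higher number from compound 3 to compound 4 (0.13 log units; within the scatter). Compound 4 is estimated at 0.85 h in this assay, expected to fall between 0.4 h and 1.8 h.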

Compound 4, half-life: 0.383 h
Beside the measured number, compound 4's estimate is 2.2-fold (0.35 log units) above it, and the stated range ends above it.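

Turning cyclopropylsulfonyl into (1-methylcyclopropyl)sulfonyl gives a 1.6-fold lower number from compound 3 to compound 4 (0.21 log units; within the scatter), so in this assay this step taken alone does not separate compound 4 from compound 3. Set beside the earlier methyl step, which also stayed within the scatter, the two steps are further apart than two such steps would be expected to lie: the same change on two cores in this assay, a 1.8-fold higher number (0.25 log units; within the scatter) from compound 1 to compound 2 and a 1.6-fold lower number (0.21 log units; within the scatter) from compound 3 to compound 4, 2.9-fold (0.47 log units) apart, beyond the scatter of two such steps This shows that, across these two cores, a methyl in place of hydrogen on a saturated ring carbon cannot be carried over as one fixed step, but it does not show what sets the two steps apart, as they differ both in the core and in the place of the methyl, and the data do not separate the two.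

The compounds shown leave open whether (1-methylcyclopropyl)sulfonyl on the core of compound 1 would give a step like the one seen on the core of compound 3, a comparison that would hold the place of the methyl constant and vary only the core. They also leave open what an ethyl group, a fluorine or a hydroxyl group in place of that methyl would do on the three-membered ring.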